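This account rests on a few compounds, and the source may have more. Where it says the series, first, only, none or still open, it means among the compounds named here.

Compound 2 `CNC(=O)N1CCCc2ccc(NC(=O)c3ccc(-c4ccn(C)n4)cc3)cc21` gives the largest of the three numbers measured in a functional assay on MV4-11 cells (Homo sapiens) for antiproliferative activity, with a stated time of 6 days, tested at 6.25 uM (a higher number here means a stronger effect of the compound at the concentration tested, a lower number a weaker effect), namely 97%, although compound 3 `CNC(=O)N1CCCc2ccc(NC(=O)c3cccc(-c4cnn(C)c4)c3)cc21`, with 93.5%, sits within the scatter of it; compound 1 `CNC(=O)N1CCCc2ccc(NC(=O)c3cccc(-c4ccccc4)c3)cc21`, with 1.39%, lies far beneath. Compound 4 `CNC(=O)N1CCCc2ccc(NC(=O)c3ccc(-c4ccncc4)cc3)cc21` differs from compound 2 by pyridin-4-yl in place of 1-methyl-1H-pyrazol-3-yl on an aromatic carbon. For the measured compounds named here, only one measured step is relevant: a number 92.1 percentage points higher from compound 1 to compound 3 (beyond the scatter), where a plain phenyl was replaced by a nitrogen-bearing five-membered ring. Compound 4 keeps a nitrogen-bearing ring, so that large gain is expected to be preserved, and the exchange of one small heteroaryl for another is expected to give a number 9 percentage points lower from compound 2 to compound 4 (within the scatter), a step not clearly beyond the scatter. Compound 4 is therefore estimated at 88%, within 55% to 100%.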

Compound 4, a percentage reported as inhibition, at one concentration (the size of the read-out at that concentration, not a potency): 88.7%
Beside the measured number, compound 4's estimate is 0.7 percentage points below it, within the range that was stated.
By their numbers in this assay, from the lowest: compound 1; then compounds 4, 3 and 2 (each within the scatter of the next).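

The change gives a number 8.3 percentage points lower from compound 2 to compound 4 (within the scatter) in this assay. On this aromatic carbon, para to a large group, a six-membered ring with one nitrogen therefore does as well as a five-membered ring with two nitrogens and a methyl group, so the high read-out does not depend on the 1-methyl-1H-pyrazol-3-yl ring alone. No measurement available here explains this match.
Still open, from the compounds shown here alone, is whether a non-aromatic group at this place, such as an amine or a carboxylic acid, would keep the effect. A single tested concentration also leaves any difference in potency between these compounds unknown.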